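The source may report more compounds than this note shows. Statements on the series, on what has been measured and on what is new or still open speak of the compounds shown alone.

Measured in a functional assay on MKN-45 cells (Homo sapiens) for cytotoxicity, read by MTT assay, with a stated time of 72 h; on this read-out higher numbers stand for weaker inhibition and lower numbers for stronger inhibition:
compound 1 `CN(C)CCn1cnnc1-c1cc(Oc2ccc(NC(=O)N/N=C/c3c[nH]c4ccccc34)cc2F)ccn1` gives 790 nM
compound 2 `CN(C)CCn1cnnc1-c1cc(Oc2ccc(NC(=O)N/N=C/c3cccc(Br)c3)cc2F)ccn1` gives 450 nM
compound 3 `CN(C)CCn1cnnc1-c1cc(Oc2ccc(NC(=O)N/N=C/c3ccc(O)cc3)cc2F)ccn1` gives 820 nM

Compound 3 carries the largest of the three numbers, but neither gap separates it from the others: a 1.0-fold higher number from compound 1 to compound 3 (0.02 log units; within the scatter) and a 1.8-fold higher number from compound 2 to compound 3 (0.26 log units; within the scatter) are both within the scatter. Compound 4 `COc1cc(/C=N/NC(=O)Nc2ccc(Oc3ccnc(-c4nncn4CCN(C)C)c3)c(F)c2)ccc1O` differs from compound 3 by methoxy in place of hydrogen on an aromatic carbon, on an aromatic carbon of a six-membered aromatic ring of carbon only, ortho to a hydroxy group, meta to a large group. All three measured steps exchange the aryl group on the carbon with a double bond to nitrogen, and none leaves the scatter, a 1.8-fold lower number from compound 1 to compound 2 (0.24 log units; within the scatter) included. A smaller addition at the same ring is therefore expected to give no step beyond the scatter in this assay, a 1.0-fold lower number from compound 3 to compound 4 (0.01 log units; within the scatter). Compound 4 is estimated at 800 nM, range 400 nM to 1600 nM.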

Compound 4, half-maximal inhibitory concentration: 3780 nM
Compound 4: middle estimate off by 4.7-fold (0.67 log units), on the low side; measured number above the stated range.
By their numbers in this assay, from the lowest: compounds 2, 1 and 3 (each within the scatter of the next); then compound 4.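

In this assay, among the compounds shown here, methoxy on an aromatic carbon ortho to a hydroxy group gives the first step beyond the scatter (a 4.6-fold higher number from compound 3 to compound 4 (0.66 log units; beyond the scatter)), so this position responds to a small addition, although exchanges of the whole aryl group among compound 1, compound 2 and compound 3 stayed within the scatter. The 4-hydroxy-3-methoxyphenyl group also stands apart from 1H-indol-3-yl (a 4.8-fold higher number from compound 1 to compound 4 (0.68 log units; beyond the scatter)) and from 3-bromophenyl (an 8.4-fold higher number from compound 2 to compound 4 (0.92 log units; beyond the scatter)). No measurement on hand accounts for these steps.

Open, going by these compounds, is whether the weaker inhibition is specific to methoxy or extends to other groups at this position, such as fluorine, an amine or ethoxy. Also open, on these data alone, is whether methoxy has the same effect on a ring without the hydroxy group.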